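The source may report more compounds than this note shows. Statements on the series, on what has been measured and on what is new or still open speak of the compounds shown alone.

Compound 1 `CCOC(=O)c1c(-c2cccc(-c3ccccc3)c2)[nH]c2cc(OC)c(F)cc2c1=O` and compound 2 `CCOC(=O)c1c(-c2cccc(OC(F)(F)F)c2)[nH]c2cc(OC)c(F)cc2c1=O` share one core and differ only in the group on the outer ring. In an ADME assay on HEK293 cells (Homo sapiens) for cytotoxicity, read by luminescence, with a stated time of 72 h (on this read-out higher numbers stand for an effect only at larger amounts of compound and lower numbers for an effect already at smaller amounts), compound 1 gives > 22000 nM, which is a limit of the assay and not a number. In this assay compound 2 gives > 22000 nM, which is also a limit and not a number. The step that the two limits leave unreadable from compound 1 to compound 2 therefore cannot be read; both values sit at the limit of > 22000 nM in this assay, at which 2 of the 2 values shown sit.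

Compound 3 `CCOC(=O)c1c(-c2cccc(Cl)c2)[nH]c2cc(OC)c(F)cc2c1=O` is the next compound in this series. It differs from compound 2 by chloro in place of trifluoromethoxy on an aromatic carbon. For the measured compounds named here, no measured step bears on this change, since the only step recorded, from compound 1 to compound 2, is itself unreadable. Both measured compounds stand at the limit, so compound 3 is expected to stand there too, with the expected step of a number no higher from compound 2 to compound 3 (the limit leaves the size open) being none beyond the scatter. The estimate for compound 3 is 22000 nM, with a range from 11000 nM to 44000 nM.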

Compound 3, half-maximal effective concentration: > 22000 nM
Compound 3: no number, only a limit; the forecaster's own chance of this, stated with the estimate: 80%; the middle value sits exactly at the limit.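

In this assay compound 3 gives > 22000 nM, which is a limit and not a number. No step among compound 1, compound 2 and compound 3 can be read: the limit of > 22000 nM in this assay, at which 3 of the 3 values shown sit.

The compounds shown leave open whether phenyl, trifluoromethoxy and chloro differ at all in their effect on these cells.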